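This account rests on a few compounds, and the source may have more. Where it says the series, first, only, none or still open, it means among the compounds named here.

Measured in a functional assay on cells (Homo sapiens) for antiproliferative activity, read by sulforhodamine B assay, with a stated time of 48 h; a lower number here means a stronger inhibitor, a higher number a weaker inhibitor:
- Compound 1 `CCCCCCCCCCCCCCNC(=O)[C@@H]1CSC(c2cc(OC)c(OC)c(OC)c2)N1`: 2000 nM
- Compound 2 `CCCCCCCCCCCCCCCCNC(=O)[C@@H]1CSC(c2cc(OC)c(OC)c(OC)c2)N1`: 1800 nM
- Compound 3 `CCCCCCCCCCNC(=O)[C@@H]1CSC(c2ccc(OC)c(OC)c2)N1`: 11900 nM

Compound 2 lies within the scatter of compound 1, and both numbers sit well under that of compound 3. Compound 4 `CCCCCCCCCCCCCCCCNC(=O)[C@@H]1CSC(c2ccc(OC)c(OC)c2)N1` is compound 2 with hydrogen in place of methoxy on an aromatic carbon, turning 3,4,5-trimethoxyphenyl into 3,4-dimethoxyphenyl: hydrogen in place of methoxy on an aromatic carbon. Among the compounds with values here, no measured step isolates this change. Within the data shown here, the only measured step, a 1.1-fold lower number from compound 1 to compound 2 (0.05 log units; within the scatter), alters the chain alone and stays within the scatter. Compound 3 carries the 3,4-dimethoxyphenyl group but also a different chain, so its 11900 nM is only a loose hint towards a higher number. The expected step in this assay is a modest rise, a 1.9-fold higher number from compound 2 to compound 4 (0.29 log units; within the scatter). For compound 4 the estimated value is 3500 nM, with an expected range of 1500 nM to 9000 nM.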

Compound 4, half-maximal inhibitory concentration: 1500 nM
The estimate for compound 4 lay 2.3-fold (0.37 log units) above the measured number, and the stated range covers the measured number.
By their numbers in this assay, from the lowest: compounds 4, 2 and 1 (each within the scatter of the next); then compound 3.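

In this assay, the step from 3,4,5-trimethoxyphenyl to 3,4-dimethoxyphenyl gives a 1.2-fold lower number from compound 2 to compound 4 (0.08 log units; within the scatter) on the long chain, so losing this methoxy leaves no visible change. Within the data shown here, the other step, a 7.9-fold lower number from compound 3 to compound 4 (0.90 log units; beyond the scatter), shows that with 3,4-dimethoxyphenyl in place, adding hexyl to the chain does change the number, which the earlier compounds could only hint at.

Whether a hydroxyl or an amine at this position would behave like hydrogen remains open, and no measurement here explains either step.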